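Cytotoxicity notes on a sulfur-for-oxygen switch at one position

The compounds below may be only part of what the source reports. "The series", "measured", "known", "first", "only" and "open" are said of these compounds alone.

Compound 1 `CCCOc1nc(N)nc2c1ncn2/C=C1/CC1(CO)CO`. In an ADME assay on HFF cells (Homo sapiens) for cytotoxicity, with a stated time of 8 days (on this read-out lower numbers stand for higher toxicity in this test and higher numbers for lower toxicity in this test), compound 1 gives > 300000 nM, which is a limit of the assay and not a number.
Compound 2 `CSc1nc(N)nc2c1ncn2/C=C1/CC1(CO)CO`. In this assay compound 2 gives > 300000 nM, again a limit of the assay.
Compound 3 `Nc1nc(SC2CCCC2)c2ncn(/C=C3/CC3(CO)CO)c2n1`. In this assay compound 3 gives > 300000 nM, again a limit of the assay.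
Compound 4 `Nc1nc(SCc2ccccc2)c2ncn(/C=C3/CC3(CO)CO)c2n1`. Compound 4 is not yet measured in this assay.

Compound 1 stands only at a limit in this assay, so no number places it relative to compound 2 or compound 3. The change that leads to compound 4 is benzylsulfanyl in place of propoxy on an aromatic carbon. The measured steps at the same position are a step that the two limits leave unreadable from compound 1 to compound 2 and a step that the two limits leave unreadable from compound 1 to compound 3; the step on the sulfur, a step that the two limits leave unreadable from compound 2 to compound 3, is unreadable in the same way. All three values sit at the limit of > 300000 nM in this assay, at which 3 of the 3 values shown sit, so none of these steps has a size that can be read, and they give no direction for the new change. For the measured compounds named here, the expectation for compound 4 is therefore a step of a number no higher from compound 1 to compound 4 (the limit leaves the size open), meaning no step that can be read beyond the scatter, with the result most likely reported again as a limit in this assay. Compound 4 is estimated at 300000 nM, with a range from 80000 nM to 300000 nM.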

Compound 4, half-maximal cytotoxic concentration: > 300000 nM
Compound 4: only a limit was reported; the forecaster's own chance of this, stated with the estimate: 80%; the middle value lies on the limit itself.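

Compound 4 joins compound 1, compound 2 and compound 3 at a limit of the assay, so no step among these compounds can be read in this assay: the limit of > 300000 nM in this assay, at which 4 of the 4 values shown sit.

The compounds shown leave open whether any group on this aromatic carbon gives a readable number, and how propoxy, methylsulfanyl, cyclopentylsulfanyl and benzylsulfanyl would then rank in this assay.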